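Swapping the aromatic substituent on a shared core

This account rests on a few compounds, and the source may have more. Where it says the series, first, only, none or still open, it means among the compounds named here.

Of the compounds shown here, three sharing one core have been measured in an assay on isolated protein for inhibition of ubiquitin carboxyl-terminal hydrolase 7 (Homo sapiens), with stated times of 30 min and 2 h; a higher number here means a weaker inhibitor, a lower number a stronger inhibitor. Compound 1 `Cc1ccc(-c2ccc(CN3CCC(O)(Cn4cnc5c(-c6ccc(CN)cc6)n(C)nc5c4=O)CC3)c(Cl)c2)s1` gives 101 nM. Compound 2 `Cn1nc2c(=O)n(CC3(O)CCN(Cc4ccc(-c5ccsc5)cc4Cl)CC3)cnc2c1-c1ccc(CN)cc1` gives 59.5 nM. Compound 3 `Cn1nc2c(=O)n(CC3(O)CCN(Cc4ccc(-c5cnco5)cc4Cl)CC3)cnc2c1-c1ccc(CN)cc1` gives 71.6 nM. Among these three numbers compound 3 stands second highest; its nearest neighbour is compound 2, separated by a 1.2-fold higher number from compound 2 to compound 3 (0.08 log units; within the scatter), and its furthest is compound 1, separated by a 1.4-fold lower number from compound 1 to compound 3 (0.15 log units; within the scatter). The remaining pair is a 1.7-fold lower number from compound 1 to compound 2 (0.23 log units; within the scatter). None of these steps passes beyond the scatter, so the three compounds are not distinguished by this assay.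

Compound 4 `Cn1nc2c(=O)n(CC3(O)CCN(Cc4ccc(-c5ccc(C(=O)O)o5)cc4Cl)CC3)cnc2c1-c1ccc(CN)cc1` has not yet been measured. It differs from compound 3 by 5-carboxyfuran-2-yl in place of 1,3-oxazol-5-yl on an aromatic carbon. The three steps already seen all exchange the group on the same aromatic carbon, and each of them is small: a 1.7-fold lower number from compound 1 to compound 2 (0.23 log units; within the scatter), a 1.4-fold lower number from compound 1 to compound 3 (0.15 log units; within the scatter) and a 1.2-fold higher number from compound 2 to compound 3 (0.08 log units; within the scatter). For the measured compounds named here, on that basis, the move to 5-carboxyfuran-2-yl is expected to give no step beyond the scatter, though the carboxylic acid is a feature none of the measured compounds carries, so the spread is widened. The expected step is a 1.0-fold lower number from compound 3 to compound 4 (0.01 log units; within the scatter). Compound 4 is therefore estimated at 70 nM in this assay, with a range from 30 nM to 170 nM.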

Compound 4, half-maximal inhibitory concentration: 753 nM
For compound 4 the middle estimate is 11-fold (1.03 log units) below the measured one; measured number outside the range, above it.
By their numbers in this assay, from the lowest: compounds 2, 3 and 1 (each within the scatter of the next); then compound 4.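

Within this assay, the aromatic carbon para to a large group is not indifferent to what it carries: the position accepted the three groups of compounds 1, 2 and 3 without a step beyond the scatter, but 5-carboxyfuran-2-yl separates clearly from all of them. The move gives a large step from 1,3-oxazol-5-yl (an 11-fold higher number from compound 3 to compound 4 (1.02 log units; beyond the scatter)) and from thiophen-3-yl (a 13-fold higher number from compound 2 to compound 4 (1.10 log units; beyond the scatter)), and a modest one from 5-methylthiophen-2-yl (a 7.5-fold higher number from compound 1 to compound 4 (0.87 log units; beyond the scatter)), so all three steps point towards a weaker inhibitor whichever of these groups is replaced. Nothing in the data shown explains this loss.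

The entering group differs from the others in both its furan ring and its carboxylic acid, and these compounds cannot say which of the two goes with the higher number, or whether the extra heavy atoms and the hydrogen-bond donor matter. An unsubstituted furan-2-yl group, or a methyl ester or primary carboxamide in place of the carboxylic acid on the same furan, would pull these features apart.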